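An untested group change on compound 2

The source may report more compounds than this note shows. Statements on the series, on what has been measured and on what is new or still open speak of the compounds shown alone.

In a functional assay on HeLa cells (Homo sapiens) for inhibition, read by MTT assay, with a stated time of 72 h (a higher number here means a weaker inhibitor, a lower number a stronger inhibitor), compound 1 `Brc1ccc(-c2nnc(SCCCN3CCN(c4nc5ccccc5o4)CC3)o2)cc1` gives 187000 nM, compound 2 `Oc1ccc(-c2nnc(SCCCN3CCN(c4nc5ccccc5o4)CC3)o2)cc1` gives 99500 nM, and compound 3 `c1ccc(-c2nnc(SCCCN3CCN(c4nc5ccccc5o4)CC3)o2)cc1` gives 67000 nM. Compound 2 lies within the scatter of both others, with a 1.9-fold lower number from compound 1 to compound 2 (0.27 log units; within the scatter) and a 1.5-fold lower number from compound 2 to compound 3 (0.17 log units; within the scatter). Only a 2.8-fold lower number from compound 1 to compound 3 (0.45 log units; beyond the scatter) goes beyond the scatter, and it is modest. Compound 4 `Oc1ccc(-c2nnc(SCCCN3CCN(c4nc5ccccc5s4)CC3)o2)cc1` keeps the hydroxy of compound 2 and changes another part: 1,3-benzothiazol-2-yl in place of 1,3-benzoxazol-2-yl on an amine nitrogen in a ring. All three measured steps swap a group on an aromatic carbon, so none tests this place directly. They show only that this series has so far moved little, at most a 2.8-fold lower number from compound 1 to compound 3 (0.45 log units; beyond the scatter). With no basis for a direction, the expected change is a 1.2-fold lower number from compound 2 to compound 4 (0.07 log units; within the scatter), none beyond the scatter. Compound 4 is estimated at 85000 nM, within a range of 30000 nM to 220000 nM.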

Compound 4, half-maximal inhibitory concentration: 139000 nM
For compound 4 the middle estimate is 1.6-fold (0.21 log units) below the measured one, within the range that was stated.
By their numbers in this assay, from the lowest: compounds 3, 2, 4 and 1 (each within the scatter of the next, the first and the last beyond it).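

Among these compounds, this step is the first test of the group on the amine nitrogen in a ring, since all earlier steps swapped a group on an aromatic carbon. In this assay the change from 1,3-benzoxazol-2-yl to 1,3-benzothiazol-2-yl, with sulfur in place of oxygen, gives a 1.4-fold higher number from compound 2 to compound 4 (0.15 log units; within the scatter) and so leaves the two groups indistinguishable when the hydroxy is kept. No measurement here offers an explanation for this result.

Still open, going by these compounds, is whether a different kind of group on that nitrogen, such as a phenyl or pyridin-2-yl ring, would move the number beyond the scatter. Also open, on these data alone, is whether 1,3-benzothiazol-2-yl behaves the same alongside the bromo of compound 1 or the hydrogen of compound 3.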